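The source may report more compounds than this note shows. Statements on the series, on what has been measured and on what is new or still open speak of the compounds shown alone.

Compound 1 `Fc1ccc(-c2cc3ccccc3[nH]2)cc1` carries a fluoro group on its six-membered aromatic ring. In an assay on isolated protein for inhibition of Aromatase (Homo sapiens), read by fluorescence, using NADPH, with a stated time of 30 min, tested at 50 uM (a lower number here means less inhibition, a higher number more inhibition at the concentration tested (going by the name of the read-out)), compound 1 gives 21.8%, the lowest of the two numbers measured. Compound 2 `O/N=C/c1c(-c2ccccc2)[nH]c2ccccc12` gives 40.4% in this assay, a number that lies above compound 1 by more than the usual scatter. Compound 3 `Brc1ccc(-c2cc3ccccc3[nH]2)cc1` differs from compound 1 by one change: bromo in place of fluoro on an aromatic carbon. Going by the values given here, no measured pair shows the effect of such a change here, so the guide is indirect. The step from compound 1 to compound 3 in this assay is expected to be a number 6.2 percentage points higher from compound 1 to compound 3 (within the scatter), a shift that stays within the scatter. Compound 3 is accordingly estimated at 28%, with a range from 10% to 48%.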

Compound 3, a percentage reported as inhibition, at one concentration (the size of the read-out at that concentration, not a potency): 4.8%
Compound 3: the middle estimate sits 23.2 percentage points above what was measured; measured number below the stated range.
By their numbers in this assay, from the lowest: compound 3; then compound 1; then compound 2.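

Bromo in place of fluoro on this aromatic carbon gives the first direct pair in this assay, with a number 17 percentage points lower from compound 1 to compound 3 (beyond the scatter). The number at this position therefore depends on which single halogen atom sits there, which neither compound 1 nor compound 2 alone could show. No measurement at hand says what lies behind this step. The compounds shown leave open how chloro, which is not among them, would compare with fluoro and bromo at this place. They also leave open whether an amine or a carboxylic acid there would raise or lower the number.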